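A few compounds are considered here, and "the series" means these few. Any claim that something is new, unique, unknown or untested is made for them only; others in the source may bear on it.

Compound 1 `O=c1[nH]cnc2c1c(-c1ccoc1)cn2[C@@H]1O[C@H](CO)[C@@H](O)[C@H]1O` carries a furan-3-yl group on the shared core. In a functional assay on HCT-116 cells (Homo sapiens), read by MTT assay, with a stated time of 72 h (a higher number here means a weaker inhibitor, a lower number a stronger inhibitor), compound 1 gives 10300 nM, the highest of the two numbers measured here. Compound 2 `COc1ncnc2c1c(-c1ccoc1)cn2[C@@H]1O[C@H](CO)[C@@H](O)[C@H]1O` gives 110 nM in this assay. Compound 3 `CN(C)c1ncnc2c1c(-c1ccoc1)cn2[C@@H]1O[C@H](CO)[C@@H](O)[C@H]1O` reaches only the limit of this assay, > 20000 nM. Among the compounds with values here, the single measured step, an at least 180-fold higher number from compound 2 to compound 3 (2.25 log units; beyond the scatter), alters a different part of the core and so says nothing about the change to compound 4 `O=c1[nH]cnc2c1c(-c1ccco1)cn2[C@@H]1O[C@H](CO)[C@@H](O)[C@H]1O`: furan-2-yl in place of furan-3-yl on an aromatic carbon. Within the data shown here, since no measured step bears on exchanging one furan attachment for the other, no step beyond the usual scatter is expected. Compound 4 is therefore estimated at 10300 nM, with a range from 3000 nM to 35000 nM. The expected step is no change at the digits printed from compound 1 to compound 4 (within the scatter), essentially flat.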

Compound 4, half-maximal inhibitory concentration: 18300 nM
Compound 4: middle estimate off by 1.8-fold (0.25 log units), on the low side; measured number inside the range.
By their numbers in this assay, from the lowest: compound 2; then compounds 1 and 4 (each within the scatter of the next). At a limit, above all of these: compound 3.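

Exchanging furan-3-yl for furan-2-yl, with the same atoms joined differently, gives a 1.8-fold higher number from compound 1 to compound 4 (0.25 log units; within the scatter), so on this aromatic carbon of the core of compound 1 the point of furan attachment makes no clear difference in this assay. Both numbers lie close to the top of the reported range, which leaves little room to see any further loss: the limit of > 20000 nM in this assay, at which 1 of the 4 values shown sits.

As far as these compounds go, it stays open whether the two furans would also match on the methoxy-bearing core of compound 2, and how a phenyl ring or an amine would fare on this carbon.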